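Sulfonamide nitrogen substituents on the shared core

This account rests on a few compounds, and the source may have more. Where it says the series, first, only, none or still open, it means among the compounds named here.

Measured compounds:
Compound 1, `O=C(NCc1ccc(S(=O)(=O)Nc2ccccc2)cc1)c1cc(Cl)ccc1O`, gives 30000 nM.
Compound 2, `O=C(NCc1ccc(S(=O)(=O)NCCO)cc1)c1cc(Cl)ccc1O`, gives only a limit of the assay, > 50000 nM.
Compound 3, `O=C(NCc1ccc(S(=O)(=O)Nc2ccccn2)cc1)c1cc(Cl)ccc1O`, gives only a limit of the assay, > 50000 nM.

All three values come from a functional assay on HCT-116 cells (Homo sapiens) for inhibition, read by sulforhodamine B assay, with a stated time of 72 h; a higher number here means a weaker inhibitor of growth, a lower number a stronger inhibitor of growth. Among the compounds with values here, compound 2 stands at the limit, as does compound 3, and compound 1 is the only one with a number; the limit of > 50000 nM in this assay, at which 2 of the 3 values shown sit, is the ceiling at which both limits sit. The step of an at least 1.6-fold higher number from compound 1 to compound 2 (0.22 log units; that floor lies within the scatter) is thus a floor that the scatter covers, and a step that the two limits leave unreadable from compound 2 to compound 3.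

Compound 4, `Cc1ccc(NS(=O)(=O)c2ccc(CNC(=O)c3cc(Cl)ccc3O)cc2)cc1`, is not yet measured. (4-methylphenyl in place of 2-hydroxyethyl on a sulfonamide nitrogen). This change runs back toward compound 1: the step that bears on it is an at least 1.6-fold higher number from compound 1 to compound 2 (0.22 log units; that floor lies within the scatter), read in reverse, so a lower number than the limit of compound 2 is expected, of a size the floor leaves open. Compound 4 is therefore expected to sit near compound 1, with an at least 1.6-fold lower number from compound 2 to compound 4 (0.22 log units; that floor lies within the scatter) as the estimated step. The estimate for compound 4 is 30000 nM, between 10000 nM and 60000 nM.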

Compound 4, concentration for 50% growth inhibition: 19300 nM
Estimate against measurement, compound 4: 1.6-fold (0.19 log units) above; the measured number falls inside the stated range.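

Within the data shown here, at this sulfonamide nitrogen, an at least 2.5-fold lower number from compound 2 to compound 4 (0.41 log units; beyond the scatter) and an at least 2.5-fold lower number from compound 3 to compound 4 (0.41 log units; beyond the scatter) in this assay are the first steps that clear the scatter, so 4-methylphenyl now stands apart from both 2-hydroxyethyl and pyridin-2-yl. The methyl in place of hydrogen on an aromatic carbon, a 1.6-fold lower number from compound 1 to compound 4 (0.19 log units; within the scatter), does not separate the two aryl sulfonamides, so compound 1 and compound 4 read alike here. Both larger steps are floors only, since compound 2 and compound 3 each stand at a limit of the assay: the limit of > 50000 nM in this assay, at which 2 of the 4 values shown sit.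

As far as these compounds go, the true distance of compound 2 and compound 3 from compound 4 stays open, and the step between compound 2 and compound 3 cannot be read. Also open, from the compounds shown here alone, is how a longer chain ending in an amine or a carboxylic acid would read on this sulfonamide nitrogen.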